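Removing One Chlorine from an Aromatic Ether

A few compounds are considered here, and "the series" means these few. Any claim that something is new, unique, unknown or untested is made for them only; others in the source may bear on it.

Of the compounds shown here, three that share a core have been measured in a functional assay on cells for agonist activity at Free fatty acid receptor 1 (Homo sapiens), read by FLIPR and calcium flux, with a stated time of 100 s; a higher number here means that more compound is needed for the effect, a lower number that less compound is needed. Compound 1 `O=C(O)C[C@H]1CCCN1c1ccc(OCc2ccc(Cl)cc2Cl)cc1` gives 880 nM, compound 2 `Cc1ccccc1COc1ccc(N2CCC[C@H]2CC(=O)O)cc1` gives 190 nM, and compound 3 `O=C(O)C[C@@H]1CCCN1c1ccc(Oc2ccc(Cl)cc2Cl)cc1` gives 360 nM. Among these three numbers compound 3 stands second highest: its nearest neighbour is compound 2, whose number is lower but within the scatter, while compound 1 lies furthest away with a higher number beyond the scatter. Among the compounds with values here, the one measured step at the same position on the oxygen is a 1.9-fold higher number from compound 2 to compound 3 (0.28 log units; within the scatter), which counts as no real change.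

Compound 4 `O=C(O)C[C@@H]1CCCN1c1ccc(Oc2cccc(Cl)c2)cc1` is not yet measured. It differs from compound 3 in one place: 3-chlorophenyl in place of 2,4-dichlorophenyl on an oxygen on an aromatic ring. Within the data shown here, no measured pair shows exactly this swap, the loss of one chlorine with the other kept. What the measured step does show is that quite different groups on this oxygen can give numbers within the scatter of each other, and compound 1 set against compound 3 shows that changes in the group on this oxygen can still move the number further. With only this to go on, the expectation for compound 4 is a number near that of compound 3, perhaps somewhat higher, a step of a 1.5-fold higher number from compound 3 to compound 4 (0.18 log units; within the scatter). Compound 4 is therefore estimated at 550 nM, with a range from 200 nM to 1600 nM.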

Compound 4, half-maximal effective concentration: 680 nM
The estimate for compound 4 lay 1.2-fold (0.09 log units) below the measured number, and the stated range covers the measured number.
By their numbers in this assay, from the lowest: compounds 2, 3, 4 and 1 (each within the scatter of the next, the first and the last beyond it).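

In this assay the direct swap of 2,4-dichlorophenyl for 3-chlorophenyl on the oxygen gives a 1.9-fold higher number from compound 3 to compound 4 (0.28 log units; within the scatter), which counts as no real change, so this group can lose a chlorine, and have its remaining chlorine named at a different ring position, without a clear effect on the number. Within the data shown here, the same position now also yields a step that clears the scatter, a 3.6-fold higher number from compound 2 to compound 4 (0.55 log units; beyond the scatter), with 3-chlorophenyl in place of 2-methylbenzyl, whereas the one step measured earlier on this oxygen stayed within the scatter. Read together, these two steps show that the choice of group on this oxygen can move the number even though the change from two chlorines to one does not do so here.

The compounds shown leave open what a phenyl with no chlorine at all would give, or a 4-chlorophenyl that keeps a chlorine at a position named in the 2,4-dichlorophenyl group, or a ring carrying a methoxy group or an amine instead of chlorine. Nothing available here explains why any of these numbers take the values they do.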